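The source may hold more compounds than are shown below. What is called first, only, known or untested is meant among the compounds shown, and "the series" means these compounds.

In an ADME assay on HEK293 cells (Homo sapiens) for cytotoxicity, read by CCK-8 assay and cell counting, with a stated time of 2 days (a higher number here means a weaker inhibitor, a lower number a stronger inhibitor), three compounds built on a shared core have been measured. Compound 1 `Oc1cccc(-c2cc(-c3ccc(Cl)cc3)nc(-c3cccnc3)c2)c1` gives 39500 nM, compound 2 `Oc1cccc(-c2cc(-c3ccccc3)nc(-c3ccc(Cl)cc3)c2)c1` gives 11600 nM, and compound 3 `Oc1ccc(-c2cc(-c3ccccc3)nc(-c3ccc(Cl)cc3)c2)cc1` gives 4810 nM. Compound 2 therefore holds the second highest of the three numbers: its nearest neighbour is compound 3, reached by a 2.4-fold lower number from compound 2 to compound 3 (0.38 log units; beyond the scatter), while compound 1 lies furthest away, with a 3.4-fold lower number from compound 1 to compound 2 (0.53 log units; beyond the scatter) separating the two.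

Compound 4 `Oc1cccc(-c2cc(-c3ccccc3)nc(-c3cccc(Cl)c3)c2)c1` has not yet been measured. It differs from compound 2 by 3-chlorophenyl in place of 4-chlorophenyl on an aromatic carbon. Going by the values given here, no measured step moves the chlorine, so none bears directly on this change. Among the compounds with values here, the only step of a similar kind, a change in the position of a group on an outer ring, is a 2.4-fold lower number from compound 2 to compound 3 (0.38 log units; beyond the scatter), which gave a modest move; the larger step, a 3.4-fold lower number from compound 1 to compound 2 (0.53 log units; beyond the scatter), exchanged one ring for another and is less comparable. A step of at most similar size, or none beyond the scatter, is therefore expected in this assay, with no clear direction. For compound 4 the estimated value in this assay is 10000 nM, with a range from 4000 nM to 30000 nM. This estimate means a step of a 1.2-fold lower number from compound 2 to compound 4 (0.06 log units; within the scatter) is expected.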

Compound 4, half-maximal inhibitory concentration: 3120 nM
Beside the measured number, compound 4's estimate is 3.2-fold (0.51 log units) above it, and the stated range ends above it.
By their numbers in this assay, from the lowest: compounds 4 and 3 (each within the scatter of the next); then compound 2; then compound 1.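

In this assay, the ring that sits next to the ring nitrogen is sensitive to where its chlorine stands: 3-chlorophenyl in place of 4-chlorophenyl gives a 3.7-fold lower number from compound 2 to compound 4 (0.57 log units; beyond the scatter) even though the two compounds have the same atoms, joined differently. Going by these compounds alone, until now, the only positional change was on the hydroxyl-bearing ring, where a 2.4-fold lower number from compound 2 to compound 3 (0.38 log units; beyond the scatter) was seen, so this result shows that moving a group on the chlorine-bearing ring also shifts the number beyond the scatter, and in the same downward direction in these two steps. Nothing shown here accounts for this shift in cytotoxicity, as no supporting measurement explains it.

The compounds shown leave open whether a methoxy group, an amine or a carboxylic acid in place of the chlorine would give a similar shift, or whether the effect belongs to chlorine alone. They also leave open whether the 4-hydroxyphenyl and 3-chlorophenyl groups, each seen here on a separate compound, would add up, cancel or do neither if carried together on the shared core.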